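Notes on the step from compound 3 to compound 4

The compounds below may be only part of what the source reports. "The series", "measured", "known", "first", "only" and "open" are said of these compounds alone.

The series has so far returned no exact number in a functional assay on L1210 cells (Mus musculus) for antiproliferative activity, read by MTT assay; on this read-out lower numbers stand for stronger inhibition and higher numbers for weaker inhibition. Compound 1 `COc1ccc(/C=N/NC(=O)c2cn(C3CC3)c3cc(N/N=C/c4ccc(OC)c(O)c4)c(F)cc3c2=O)cc1O` gives <= 25000 nM, which is a limit and not a number. Compound 2 `O=C(N/N=C/c1ccccc1[N+](=O)[O-])c1cn(C2CC2)c2cc(N/N=C/c3ccccc3[N+](=O)[O-])c(F)cc2c1=O` gives <= 25000 nM, again a limit. Compound 3 `O=C(N/N=C/c1ccccc1O)c1cn(C2CC2)c2cc(N3CCNCC3)c(F)cc2c1=O` gives <= 25000 nM, also a limit. All of the measured compounds therefore sit together at the limit of <= 25000 nM in this assay, at which 3 of the 3 values shown sit, and no order among them can be read.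

Compound 4 `COc1ccc(/C=N/NC(=O)c2cn(C3CC3)c3cc(N4CCNCC4)c(F)cc3c2=O)cc1O` changes one group of compound 3: 3-hydroxy-4-methoxyphenyl in place of 2-hydroxyphenyl on a carbon with a double bond to nitrogen. In words, this places 3-hydroxy-4-methoxyphenyl in place of 2-hydroxyphenyl on a carbon with a double bond to nitrogen. Compound 1 also carries 3-hydroxy-4-methoxyphenyl and gives <= 25000 nM, a limit.

Going by the values given here, with no measured step to draw on, no change beyond the scatter is expected in this assay. The estimated step is a step that the limit leaves unreadable from compound 3 to compound 4. For compound 4 the estimate is 15000 nM, with an expected range from 3000 nM to 25000 nM.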

Compound 4, half-maximal inhibitory concentration: <= 25000 nM
Compound 4 gave a limit, no number; the forecaster's own chance of this, stated with the estimate: 70%; the middle value lies beyond the limit too.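

Compound 4 gives <= 25000 nM in this assay as a limit. The steps to it from compound 1 and compound 3 therefore cannot be read: the limit of <= 25000 nM in this assay, at which 4 of the 4 values shown sit.

In this assay the compounds shown leave open whether any of these group changes shifts the read-out at all.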